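Urea series: replacing trifluoromethyl on the fused core

This account rests on a few compounds, and the source may have more. Where it says the series, first, only, none or still open, it means among the compounds named here.

Measured so far in a functional assay on MDA-MB-231 cells (Homo sapiens) for cytotoxicity, read by MTT assay, with a stated time of 72 h; a higher number here means a weaker inhibitor, a lower number a stronger inhibitor:
compound 1 `O=C(Nc1ccc(-n2ncc3c(C(F)(F)F)cccc32)cc1)Nc1ccc(Cl)c(C(F)(F)F)c1`, 2000 nM
compound 2 `O=C(Nc1ccc(-n2ncc3ccccc32)cc1)Nc1ccc(Cl)c(C(F)(F)F)c1`, 5000 nM
compound 3 `CNc1cccc2c1cnn2-c1ccc(NC(=O)Nc2ccc(Cl)c(C(F)(F)F)c2)cc1`, 3600 nM

The three ureas share one core and differ only in the group on an aromatic carbon of the fused part. Compound 1 has the lowest number of the three. The step of a 2.5-fold higher number from compound 1 to compound 2 (0.40 log units; beyond the scatter) is beyond the scatter, whereas a 1.8-fold higher number from compound 1 to compound 3 (0.26 log units; within the scatter) lies within it, as does a 1.4-fold lower number from compound 2 to compound 3 (0.14 log units; within the scatter); compound 2 and compound 3 cannot be told apart on these numbers.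

Compound 4 `COc1cccc2c1cnn2-c1ccc(NC(=O)Nc2ccc(Cl)c(C(F)(F)F)c2)cc1` differs from compound 1 in one place: methoxy in place of trifluoromethyl on an aromatic carbon. The step that bears most directly on this change is a 1.8-fold higher number from compound 1 to compound 3 (0.26 log units; within the scatter), where methylamino replaces trifluoromethyl on the same aromatic carbon; the step of a 2.5-fold higher number from compound 1 to compound 2 (0.40 log units; beyond the scatter) marks the larger shift seen so far when trifluoromethyl leaves this carbon. A modest rise in number is therefore expected for compound 4, on the order of a 1.8-fold higher number from compound 1 to compound 4 (0.24 log units; within the scatter). The estimate for compound 4 in this assay is 3500 nM, with a range from 1800 nM to 7000 nM.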

Compound 4, half-maximal inhibitory concentration: 1200 nM
For compound 4 the middle estimate is 2.9-fold (0.46 log units) above the measured one; measured number outside the range, below it.
By their numbers in this assay, from the lowest: compounds 4, 1, 3 and 2 (each within the scatter of the next, the first and the last beyond it).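

In this assay, methoxy and methylamino on this aromatic carbon do not give the same result, with a 3.0-fold lower number from compound 3 to compound 4 (0.48 log units; beyond the scatter), and methoxy also separates from the unsubstituted carbon, with a 4.2-fold lower number from compound 2 to compound 4 (0.62 log units; beyond the scatter). With a 1.7-fold lower number from compound 1 to compound 4 (0.22 log units; within the scatter), methoxy and trifluoromethyl cannot be told apart, so losing trifluoromethyl from this carbon does not by itself raise the number, as compound 2 alone had suggested. No measurement on hand accounts for the separation of methoxy from methylamino or hydrogen at this carbon.

As far as these compounds go, whether a longer chain such as ethoxy keeps the number close to that of compound 4 remains open. Also open, from the compounds shown here alone, is whether hydroxyl or dimethylamino on this carbon would group with methoxy or with methylamino.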